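Side-chain variation on the shared core: cytotoxicity notes

The source may report more compounds than this note shows. Statements on the series, on what has been measured and on what is new or still open speak of the compounds shown alone.

The three measured compounds share one core and differ only in the substituent on a nitrogen on an aromatic ring. Compound 1 `Cc1nc(NC(C)C)nc(N[C@@H]2C[C@H](CO)[C@@H](O)[C@H]2O)c1-c1nc2ccccc2s1` gives 13000 nM in an ADME assay on cells (Homo sapiens) for cytotoxicity, read by polymerase chain reaction, with a stated time of 3 days; a lower number here means that less compound is tolerated, a higher number that more compound is tolerated. Compound 2 `COCCNc1nc(C)c(-c2nc3ccccc3s2)c(N[C@@H]2C[C@H](CO)[C@@H](O)[C@H]2O)n1` gives 21000 nM in this assay. Compound 3 `Cc1nc(NCCNC(=O)NC(C)(C)C)nc(N[C@@H]2C[C@H](CO)[C@@H](O)[C@H]2O)c1-c1nc2ccccc2s1` gives > 25000 nM in this assay, which is a limit of the assay and not a number. Compound 3 therefore stands at the limit of > 25000 nM in this assay, at which 1 of the 3 values shown sits. The steps among the measured compounds, a 1.6-fold higher number from compound 1 to compound 2 (0.21 log units; within the scatter), an at least 1.9-fold higher number from compound 1 to compound 3 (0.28 log units; that floor lies within the scatter) and an at least 1.1-fold higher number from compound 2 to compound 3 (0.07 log units; that floor lies within the scatter), are all within the scatter.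

Compound 4 `Cc1nc(NCCCC(F)(F)F)nc(N[C@@H]2C[C@H](CO)[C@@H](O)[C@H]2O)c1-c1nc2ccccc2s1` differs from compound 3 by 2,2,2-trifluoroethyl in place of ((tert-butyl)carbamoyl)amino on a saturated chain carbon, two bonds along the chain from a nitrogen on an aromatic ring. Among the measured compounds shown here, the steps that bear on this change are the three exchanges of the same side chain, and none of them reaches beyond the scatter. For compound 4 no step beyond the scatter is expected in this assay, so the expected step is an at least 1.2-fold lower number from compound 3 to compound 4 (0.09 log units; that floor lies within the scatter). Compound 4 is accordingly estimated at 20000 nM in this assay, with a range from 8000 nM to 50000 nM.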

Compound 4, half-maximal cytotoxic concentration: 3000 nM
Compound 4: middle estimate off by 6.7-fold (0.82 log units), on the high side; the whole stated range lies above it.
By their numbers in this assay, from the lowest: compound 4; then compounds 1 and 2 (each within the scatter of the next). At a limit, above all of these: compound 3.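

Side-chain notes after compound 4

This position on the shared core is not silent in this assay: with the 4,4,4-trifluorobutyl chain, less compound is tolerated, and the series shows its first steps beyond the scatter, a 7.0-fold lower number from compound 2 to compound 4 (0.85 log units; beyond the scatter) and a 4.3-fold lower number from compound 1 to compound 4 (0.64 log units; beyond the scatter). The exchange for the urea-bearing chain points the same way, but an at least 8.3-fold lower number from compound 3 to compound 4 (0.92 log units; beyond the scatter) is only a floor. Compound 3 stands at a limit of the assay, not at a number: the limit of > 25000 nM in this assay, at which 1 of the 4 values shown sits.

The compounds shown leave open whether the step follows the three fluorine atoms or the length of the chain. A plain butyl chain would separate the two readings, and a longer chain ending in trifluoromethyl or a chain ending in an amine would show how far the effect on tolerated concentration extends.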